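This account rests on a few compounds, and the source may have more. Where it says the series, first, only, none or still open, it means among the compounds named here.

Measured so far in an ADME assay on Vero cells (Chlorocebus sabaeus) for cytotoxicity, read by MTT assay, with a stated time of 72 h; on this read-out higher numbers stand for weaker inhibition and lower numbers for stronger inhibition:
compound 1 `CC1CN(c2nc3c(cc2[N+](=O)[O-])c(=O)c(C(=O)O)cn3C2CC2)CC(C)O1` gives > 160000 nM as a limit of the assay
compound 2 `O=C(O)c1cn(C2CC2)c2nc(N3CCC(n4c(=O)[nH]c5cc(Cl)ccc54)CC3)c([N+](=O)[O-])cc2c1=O` gives 55500 nM as a number
compound 3 `CC1CN(c2nc3c(cc2[N+](=O)[O-])c(=O)c(C(=O)O)cn3-c2ccc(F)cc2)CC(C)O1` gives 141000 nM as a number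

In this assay compound 3 at 141000 nM holds the higher of the two true numbers, and compound 2 at 55500 nM lies lower by more than the scatter. Compound 1 stands at a limit and has no number.

Compound 4 `O=C(O)c1cn2c(n1)CN(c1nc3c(cc1[N+](=O)[O-])c(=O)c(C(=O)O)cn3-c1ccc(F)cc1)CC2` has not yet been measured. It departs from compound 3 on an aromatic carbon ortho to a nitro group, where a group of 12 heavy atoms (7 carbon, 3 nitrogen, 2 oxygen; one five-membered aromatic ring with 2 hetero atoms, one six-membered non-aromatic ring with 2 hetero atoms) in place of a group of 8 heavy atoms (6 carbon, 1 nitrogen, 1 oxygen; one six-membered non-aromatic ring with 2 hetero atoms), on an aromatic carbon is the whole change.

Among the compounds with values here, no measured step touches that carbon. Within the data shown here, the one step available is an at least 1.1-fold lower number from compound 1 to compound 3 (0.05 log units; that floor lies within the scatter) and it concerns the group on an aromatic nitrogen instead, resting on the limit of > 160000 nM in this assay, at which 1 of the 3 values shown sits, and so saying little here. The only indirect hint is that compound 2 carries yet another group on that carbon and gives 55500 nM with cyclopropyl rather than 4-fluorophenyl on the nitrogen. A small move towards a lower number is therefore expected, most likely not beyond the scatter. The estimated change is a 1.3-fold lower number from compound 3 to compound 4 (0.11 log units; within the scatter) and no larger step is expected. For compound 4 the expected value is 110000 nM within an estimated range of 45000 nM to 220000 nM for this measurement.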

Compound 4, half-maximal inhibitory concentration: > 126000 nM
Compound 4: a limit, no number (the forecaster's own chance of this, stated with the estimate: 30%); middle value at least 1.1-fold (0.05 log units) from the limit.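

In this assay compound 4 gives > 126000 nM, which is a limit of the assay and not a number. The step from compound 3 to compound 4 therefore cannot be read: the limit of > 126000 nM in this assay, at which 1 of the 4 values shown sits.

The compounds shown leave open whether replacing 2,6-dimethylmorpholin-4-yl with the group in compound 4 moves the number in either direction, and by how much.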